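The source may hold more compounds than are shown below. What is called first, only, known or untested is meant among the compounds shown, and "the series" means these compounds.

The two compounds whose structures are known here share one core: compound 1, with the structure `CC(C(=O)NCc1ccccc1Cl)N1C(=O)CCC1=O`, and compound 2, with the structure `CC(C(=O)NCc1ccc(Cl)cc1)N1C(=O)CCC1=O`. Only one of them carries a number. In a functional assay on the whole organism (strain Albino Swiss CD1) with Mus musculus as the target (on this read-out lower numbers stand for an effect already at smaller amounts and higher numbers for an effect only at larger amounts of compound), compound 2 gives 43.6 mg/kg. For compound 1 the entry in this assay reads "not determined" (no result reported), so nothing can be said about how the two compare. Compound 2 is therefore the sole measured reference on this read-out.

Compound 3, with the structure `CCC(C(=O)NCc1ccc(Cl)cc1)N1C(=O)CCC1=O`, has not yet been measured. It differs from compound 2 in one place: methyl in place of hydrogen on a saturated chain carbon, two bonds along the chain from an amide-type nitrogen in a ring and a carbonyl carbon. Put another way, the short side chain on the carbon that links the ring and the amide grows by a single carbon.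

Going by the values given here, with no step between measured compounds available, nothing in the data points to a large shift in either direction for such a small addition. The expectation for compound 3 is a step from compound 2 that stays within the usual scatter, a 1.0-fold higher number from compound 2 to compound 3 (0.01 log units; within the scatter). On that basis compound 3 is estimated to give 45 mg/kg in this assay, with a likely range from 20 mg/kg to 100 mg/kg.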

Compound 3, dose for half-maximal effect: 50.8 mg/kg
The estimate for compound 3 lay 1.1-fold (0.05 log units) below the measured number; the range from low to high includes it.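

In this assay, going by these compounds alone, the step between these two compounds is the first that can be read: a 1.2-fold higher number from compound 2 to compound 3 (0.07 log units; within the scatter). This shows that the side chain on the carbon linking the ring and the amide can grow from methyl to ethyl, a single added carbon, without a difference that repeated measurements could separate from their ordinary spread, so at this position the read-out does not respond to a change of this size. Nothing available here accounts for this outcome.

A single small step at a single position cannot show how far this insensitivity extends: a longer chain such as propyl, or a ring such as phenyl, on the same carbon might give a number well away from those of compound 2 and compound 3. An amine or a carboxylic acid at the end of that side chain is just as open, since both ethyl and methyl are plain carbon groups and say nothing about how a chain carrying other atoms would behave.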